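This account rests on a few compounds, and the source may have more. Where it says the series, first, only, none or still open, it means among the compounds named here.

Measured so far in a functional assay on HL-60 cells (Homo sapiens) for antiproliferative activity, read by sulforhodamine B assay, with a stated time of 72 h; on this read-out lower numbers stand for stronger inhibition and higher numbers for weaker inhibition:
- compound 1 `S=C(N/N=C/c1ccc2ccccc2n1)Nc1cccc(Cl)c1`: 28800 nM
- compound 2 `CN(C)C(=S)N/N=C/c1nc2ccccc2s1`: 3680 nM
- compound 3 `NC(=S)N/N=C/c1cnc2ccccc2n1`: > 100000 nM, a limit, not a number

Compound 1 gives the highest of the two numbers; the nearer is compound 2, and that gap lies beyond the scatter. Compound 3 stops at a limit of > 100000 nM in this assay, at which 1 of the 3 values shown sits, and offers no number for comparison.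

Compound 4 `S=C(N/N=C/c1ccc2ccccc2n1)Nc1ccccc1` is not yet measured. It differs from compound 1 in one place: hydrogen in place of chloro on an aromatic carbon. For the measured compounds named here, no step between measured compounds is given, so this change has no precedent. The expectation is a small step, none beyond the scatter, or at most a slight move toward weaker inhibition. Compound 4 is therefore estimated at 40000 nM, between 12000 nM and 100000 nM. That estimate means an expected step of a 1.4-fold higher number from compound 1 to compound 4 (0.14 log units; within the scatter).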

Compound 4, half-maximal inhibitory concentration: 9130 nM
Beside the measured number, compound 4's estimate is 4.4-fold (0.64 log units) above it; the measured number lies below the stated range.
By their numbers in this assay, from the lowest: compound 2; then compound 4; then compound 1. At a limit, above all of these: compound 3.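

In this assay the series gains its first step in one place, 3-chlorophenyl to phenyl: a 3.2-fold lower number from compound 1 to compound 4 (0.50 log units; beyond the scatter). On this single pair, chloro on this aromatic carbon goes with weaker inhibition, and the core of compound 4 needs no such group for its activity. Nothing measured here accounts for the step. Open, going by these compounds, is whether fluoro, methoxy or an amine on the same aromatic carbon would read closer to chloro or to hydrogen. Also open, on these data alone, is whether the step holds on another core.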